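Leucine-tRNA ligase series: a methylpyrimidine variant of compound 1

The source may hold more compounds than are shown below. What is called first, only, known or untested is meant among the compounds shown, and "the series" means these compounds.

Measured so far:
compound 1, `CC(C)C[C@H](N)C(=O)NS(=O)(=O)c1cccc(-c2ccccc2)c1`: 3400 nM
compound 2, `CC(C)C[C@H](N)C(=O)NS(=O)(=O)c1cccc(-c2ccnc(N)c2)c1`: 490 nM
compound 3, `CC(C)C[C@H](N)C(=O)NS(=O)(=O)c1cccc(-c2ccnc(N)n2)c1`: 3900 nM

All three share one core and differ only in the aromatic group attached to it. In an assay on isolated protein for inhibition of leucine--tRNA ligase, cytoplasmic (Homo sapiens) (a higher number here means a weaker inhibitor, a lower number a stronger inhibitor), compound 1 gives 3400 nM and stands second highest of the three numbers; compound 3 is nearest, and that gap, a 1.1-fold higher number from compound 1 to compound 3 (0.06 log units; within the scatter), is within the scatter, while compound 2 lies furthest, a 6.9-fold lower number from compound 1 to compound 2 (0.84 log units; beyond the scatter). Between the two heteroaryl compounds the step of an 8.0-fold higher number from compound 2 to compound 3 (0.90 log units; beyond the scatter) is beyond the scatter.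

Compound 4, `Cc1cc(-c2cccc(S(=O)(=O)NC(=O)[C@@H](N)CC(C)C)c2)ncn1`, is not yet measured. Against compound 1 it carries 6-methylpyrimidin-4-yl in place of phenyl on an aromatic carbon. Going by the values given here, two measured steps bear on it: a 1.1-fold higher number from compound 1 to compound 3 (0.06 log units; within the scatter), where a pyrimidine ring carrying an amino group left the number unchanged, and a 6.9-fold lower number from compound 1 to compound 2 (0.84 log units; beyond the scatter), where the gain came with a pyridine ring and the same amino group. Compound 4 has the pyrimidine ring of compound 3 but a methyl group in place of its amino group; nothing measured tells what the methyl group does on its own. The expectation for this assay is therefore a step of a 1.2-fold higher number from compound 1 to compound 4 (0.07 log units; within the scatter) that stays within the scatter, with wide uncertainty. Compound 4 is estimated at 4000 nM, between 1500 nM and 12000 nM.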

Compound 4, half-maximal inhibitory concentration: 2000 nM
Estimate against measurement, compound 4: 2.0-fold (0.30 log units) above, and the stated range covers the measured number.
By their numbers in this assay, from the lowest: compound 2; then compounds 4, 1 and 3 (each within the scatter of the next).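

In this assay, the steps of a 1.7-fold lower number from compound 1 to compound 4 (0.23 log units; within the scatter) and a 2.0-fold lower number from compound 3 to compound 4 (0.29 log units; within the scatter) both lie within the scatter, so at this position, on an aromatic carbon meta to a large group, 6-methylpyrimidin-4-yl cannot be told apart from phenyl or from 2-aminopyrimidin-4-yl. Going by these compounds alone, the pyrimidine ring has now been read with a methyl group and with an amino group, and neither compound separates from compound 1, whereas the step of a 4.1-fold higher number from compound 2 to compound 4 (0.61 log units; beyond the scatter) lies beyond the scatter and leaves compound 2, with 2-aminopyridin-4-yl, as the only compound of the four clearly apart from the others. No measurement on hand accounts for any of these steps.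

Still open, as far as these compounds go, is whether the separation of compound 2 belongs to its pyridine ring or to the amino group on that ring, a question that a methyl group in place of that amine, or an aminophenyl group in place of 2-aminopyridin-4-yl, would address. Also open, from the compounds shown here alone, is whether a larger group on the pyrimidine ring, such as a methoxy group or a carboxylic acid, would move the number beyond the scatter from compound 1.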